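Adding a Second Chloro to Compound 2

The source may report more compounds than this note shows. Statements on the series, on what has been measured and on what is new or still open speak of the compounds shown alone.

In a functional assay on SW480 cells (Homo sapiens) for antiproliferative activity, read by MTT assay, with a stated time of 48 h (on this read-out lower numbers stand for stronger inhibition and higher numbers for weaker inhibition), compound 1 `CCCCCCC(CCO)n1cnc2c(Cl)nc(Cl)nc21` gives 12400 nM and compound 2 `CCCCCCCC(CCO)n1cnc2c(Cl)ncnc21` gives 3630 nM as the lower of the two numbers, a gap that lies beyond the scatter. Compound 3 `CCCCCCCC(CCO)n1cnc2c(Cl)nc(Cl)nc21` has not yet been measured. It differs from compound 2 in one place: chloro in place of hydrogen on an aromatic carbon with chloro in place of hydrogen on an aromatic carbon, between two ring nitrogen atoms. For the measured compounds named here, no measured pair shows this change alone, so its size cannot be read directly from the data. The higher number of compound 1 at 12400 nM leaves room for a move toward weaker inhibition. The expected step of a 1.4-fold higher number from compound 2 to compound 3 (0.14 log units; within the scatter) is small, toward weaker inhibition and within the scatter. In this assay the estimate for compound 3 is 5000 nM (expected range 2000 nM to 12500 nM).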

Compound 3, half-maximal inhibitory concentration: 13600 nM
For compound 3 the middle estimate is 2.7-fold (0.43 log units) below the measured one; the measured number lies above the stated range.
By their numbers in this assay, from the lowest: compound 2; then compounds 1 and 3 (each within the scatter of the next).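

In this assay the change of chloro in place of hydrogen on an aromatic carbon, between two ring nitrogen atoms, now has a measured size of a 3.7-fold higher number from compound 2 to compound 3 (0.57 log units; beyond the scatter) and goes toward weaker inhibition, so on this chain the position is not indifferent to the group. The chain change tells a different story in the presence of that chloro, since methyl in place of hydrogen on a saturated chain carbon gives a 1.1-fold higher number from compound 1 to compound 3 (0.04 log units; within the scatter) and leaves the two compounds within the scatter of each other. Nothing available bears on the reason for the chloro step.

From the compounds shown here alone, whether an amine, a methoxy group or a fluoro at this position would read closer to compound 2 stays open. Also open, going by these compounds, is how the chloro step would read on the chain of compound 1, and what a longer chain would do.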